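Swapping a para substituent on a weakly cytotoxic benzothiazole ether

The source may hold more compounds than are shown below. What is called first, only, known or untested is meant among the compounds shown, and "the series" means these compounds.

Of the compounds shown here, two sharing a common core have been tested in a functional assay on COLO 205 cells (Homo sapiens) for cytotoxicity, read by MTT assay, with a stated time of 24 h; a higher number here means a weaker inhibitor, a lower number a stronger inhibitor. Compound 1, `Fc1ccc(-n2cc(COc3ccccc3-c3nc4ccccc4s3)nn2)cc1`, gives 18900 nM. Compound 2, `FC(F)(F)Oc1ccc(-c2cc(COc3ccccc3-c3nc4ccccc4s3)on2)cc1`, gives 19900 nM. The two numbers lie within the usual scatter of each other, so the data show no real separation between them, and both sit at the weak end of what this kind of measurement resolves.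

The next compound, compound 3, `Cc1ccc(-c2cc(COc3ccccc3-c3nc4ccccc4s3)on2)cc1`, differs from compound 2 in one place: methyl in place of trifluoromethoxy on an aromatic carbon. The group that leaves has several heavy atoms and one hydrogen-bond acceptor; the one that enters is a single carbon with none. Among the compounds with values here, no measured pair yet shows what this exchange does in this assay, so the step of a 1.0-fold higher number from compound 2 to compound 3 (0.00 log units; within the scatter) is expected to stay within the scatter, in no particular direction. Compound 3 is therefore estimated at 20000 nM, with a plausible range from 8000 nM to 50000 nM.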

Compound 3, half-maximal inhibitory concentration: 14200 nM
The estimate for compound 3 lay 1.4-fold (0.15 log units) above the measured number; the range from low to high includes it.
By their numbers in this assay, from the lowest: compounds 3, 1 and 2 (each within the scatter of the next).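

In this assay, within the data shown here, exchanging 4-(trifluoromethoxy)phenyl for 4-methylphenyl gives a 1.4-fold lower number from compound 2 to compound 3 (0.15 log units; within the scatter) and so provides the only measured pair here that differs in one place. At this aromatic carbon, para to a large group, trifluoromethoxy and methyl therefore give numbers that cannot be told apart, even though the two groups differ in size and in hydrogen-bond acceptors. No outside measurement is available to help interpret this result.

Still open, from the compounds shown here alone, is whether an amine, a carboxylic acid or a longer alkyl chain at this position would shift the number beyond the scatter. Going by these compounds, it also remains unknown whether the same exchange from trifluoromethoxy to methyl would give a similar outcome on a different core, such as that of compound 1.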